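Hydroxy in Place of Benzyl on the Ring Nitrogen

This account rests on a few compounds, and the source may have more. Where it says the series, first, only, none or still open, it means among the compounds named here.

In a functional assay on the whole organism (strain ICR) with Mus musculus as the target, in the maximal electroshock model, with a stated time of 30 min (a lower number here means that less compound is needed, a higher number that more compound is needed for the effect), compound 1 `CN1C(=O)COCC(NC(=O)OCc2ccccc2)C1=O` gives 68.8 mg/kg, and compound 2 `CCCCCCN1C(=O)COCC(NC(=O)OCc2ccccc2)C1=O` gives 87.5 mg/kg in this assay. Compound 3 `O=C(NC1COCC(=O)N(Cc2ccccc2)C1=O)OCc1ccccc1` is known in this assay only as the limit > 100 mg/kg, which is a limit of the assay and not a number, as the limit of > 100 mg/kg in this assay, at which 1 of the 3 values shown sits, shows. Compound 4 `O=C(NC1COCC(=O)N(O)C1=O)OCc1ccccc1` has not been measured; the change from compound 3 is hydroxy in place of benzyl on an amide-type nitrogen in a ring. Three measured steps alter the group on that same ring nitrogen: a 1.3-fold higher number from compound 1 to compound 2 (0.10 log units; within the scatter), an at least 1.4-fold higher number from compound 1 to compound 3 (0.16 log units; that floor lies within the scatter) and an at least 1.1-fold higher number from compound 2 to compound 3 (0.05 log units; that floor lies within the scatter). Across those steps the number changes little, with the larger benzyl group sitting at the limit. None of them brings in a hydroxy, so the direction of this step is open. Compound 4 is therefore expected to land near compounds 1 and 2 rather than beyond them, with an estimated 80 mg/kg in the range 40 mg/kg to 160 mg/kg. The expected step is an at least 1.2-fold lower number from compound 3 to compound 4 (0.09 log units; that floor lies within the scatter), with a real chance that only a limit is reported again.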

Compound 4, dose for half-maximal effect: 93.8 mg/kg
Compound 4: middle estimate off by 1.2-fold (0.07 log units), on the low side, and the stated range covers the measured number.
By their numbers in this assay, from the lowest: compounds 1, 2 and 4 (each within the scatter of the next). At a limit, above all of these: compound 3.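

Compound 3 stands at > 100 mg/kg, which is a limit of the assay and not a number. Compound 4 shows that a hydroxy, with its hydrogen-bond donor, can sit on this amide-type nitrogen and still give a measured number in this assay, although the step from benzyl, an at least 1.0-fold lower number from compound 3 to compound 4 (0.02 log units; that floor lies within the scatter), says little on its own. The steps from the two chains, a 1.1-fold higher number from compound 2 to compound 4 (0.03 log units; within the scatter) and a 1.4-fold higher number from compound 1 to compound 4 (0.13 log units; within the scatter), show that hydroxy, hexyl and methyl on this nitrogen cannot be told apart in this assay.

As far as these compounds go, whether a methoxy or an aminoethyl chain on the same nitrogen would also stay level with compounds 1, 2 and 4 remains open. Also open is whether any group here can move the number beyond the scatter, as no step shown does.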